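This account rests on a few compounds, and the source may have more. Where it says the series, first, only, none or still open, it means among the compounds named here.

Compound 2, `CCCCOc1cccc(-c2[nH]c3cc(OC)ccc3c(=O)c2C(=O)OCC)c1`, is measured in an ADME assay on Raji cells (Homo sapiens) for cytotoxicity, read by luminescence, with a stated time of 72 h (on this read-out lower numbers stand for an effect already at smaller amounts and higher numbers for an effect only at larger amounts of compound), and gives > 21500 nM, which is a limit of the assay and not a number. Compound 1, `CCOC(=O)c1c(-c2cccc(OCC)c2)[nH]c2cc(OC)ccc2c1=O`, gives > 21500 nM in this assay, again only a limit. Among the compounds with values here, the one measured step, a step that the two limits leave unreadable from compound 1 to compound 2, is therefore unreadable in size. The evidence amounts to the limit of > 21500 nM in this assay, at which 2 of the 2 values shown sit. Compound 3, `CCOC(=O)c1c(-c2cccc(Oc3ccccc3)c2)[nH]c2cc(OC)ccc2c1=O`, is not yet measured; it differs from compound 2 by phenyl in place of butyl on an oxygen on an aromatic ring. No measured step bears readably on this change, so no size or direction can be taken from the numbers shown. The expectation is that compound 3 again lies at the limit in this assay, so that a step that the limit leaves unreadable from compound 2 to compound 3 is the step estimated. Compound 3 is estimated at 25000 nM, with a range from 8000 nM to 80000 nM, and most likely reported as a limit.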

Compound 3, half-maximal effective concentration: > 21500 nM
Compound 3: only a limit was reported; the forecaster's own chance of this, stated with the estimate: 75%; the middle value lies beyond the limit too.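

Within the data shown here, compound 3 gives > 21500 nM in this assay, which is a limit and not a number, so no step among compound 1, compound 2 and compound 3 can be read. The compounds shown leave open whether any group on that oxygen on an aromatic ring gives a measurable value in this assay.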